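Amide side group: from compound 2 to compound 3

A few compounds are considered here, and "the series" means these few. Any claim that something is new, unique, unknown or untested is made for them only; others in the source may bear on it.

Compound 1 `Cc1ccc(C(=O)Nc2cn3ncnc3c(CN3CCN(C(=O)CC(C(F)(F)F)C(F)(F)F)[C@@H](C)C3)c2C)cn1` gives < 10 mL.min-1.g-1 (a limit of the assay)
Compound 2 `Cc1ccc(C(=O)Nc2cn3ncnc3c(CN3CCN(C(=O)C4CCCC4)[C@@H](C)C3)c2C)cn1` gives 32 mL.min-1.g-1 (a measured number)

Among the compounds with values here, in an ADME assay on microsomes from liver (Homo sapiens) for metabolic stability (a lower number here means slower removal, a higher number faster removal of the compound), compound 2 gives 32 mL.min-1.g-1 as the only true number so far. The other value is a limit. Compound 3 `Cc1ccc(C(=O)Nc2cn3ncnc3c(CN3CCN(C(=O)CC(C)C)[C@@H](C)C3)c2C)cn1` carries isobutyl in place of cyclopentyl on a carbonyl carbon. Within the data shown here, the only measured step at this place is an at least 3.2-fold higher number from compound 1 to compound 2 (0.50 log units; beyond the scatter) and it involved a different entering group, so its size is not expected to carry over. In this assay the expected step is a 1.2-fold lower number from compound 2 to compound 3 (0.09 log units; within the scatter) and it should stay within the scatter. For compound 3 the estimated value is 26 mL.min-1.g-1 (13 mL.min-1.g-1 to 50 mL.min-1.g-1).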

Compound 3, intrinsic clearance in microsomes: 20 mL.min-1.g-1
Compound 3: middle estimate off by 1.3-fold (0.11 log units), on the high side, within the range that was stated.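

In this assay, an open chain serves at this place on the carbonyl carbon as well as a ring within the usual scatter: a 1.6-fold lower number from compound 2 to compound 3 (0.20 log units; within the scatter). Against the doubly fluorinated side group, the isobutyl amide gives only a floor, and that floor does not clear the scatter: an at least 2.0-fold higher number from compound 1 to compound 3 (0.30 log units; that floor lies within the scatter). Compound 1 stands at a limit of the assay, not a number: the limit of < 10 mL.min-1.g-1 in this assay, at which 1 of the 3 values shown sits.

Open, from the compounds shown here alone, is how the number moves with an amine or a hydroxyl on this chain, or with a longer chain. Also open, going by these compounds, is where an isobutyl chain carrying a single trifluoromethyl would fall.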